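The compounds below may be only part of what the source reports. "The series", "measured", "known", "first", "only" and "open" are said of these compounds alone.

The three measured compounds share one core and differ only in the group attached to the carbonyl carbon. In a functional assay on MDA-MB-468 cells (Homo sapiens) for antiproliferative activity, read by MTT assay, with a stated time of 72 h (a lower number here means a stronger inhibitor, a higher number a weaker inhibitor), compound 1 `O=C(Nc1ccc(Cl)c(-c2nnc3c(Cl)cccn23)c1)c1ccc(C(F)(F)F)cc1F` gives 22300 nM, the lower of the two numbers measured. In this assay compound 2 `O=C(Nc1ccc(Cl)c(-c2nnc3c(Cl)cccn23)c1)c1cccc(Cl)c1` gives 54800 nM, a gap from compound 1 that lies beyond the usual scatter. In this assay compound 3 `O=C(Nc1ccc(Cl)c(-c2nnc3c(Cl)cccn23)c1)c1ccon1` gives > 100000 nM, which is a limit of the assay and not a number. Among the measured compounds shown here, the one measured step, an at least 1.8-fold higher number from compound 2 to compound 3 (0.26 log units; that floor lies within the scatter), exchanges the whole ring on the carbonyl carbon. Compound 4 `O=C(Nc1ccc(Cl)c(-c2nnc3c(Cl)cccn23)c1)c1ccc(C(F)(F)F)cc1Cl` differs from compound 1 by chloro in place of fluoro on an aromatic carbon. For the measured compounds named here, no measured step swaps one halogen for another, so a step within the scatter is expected: a 1.1-fold lower number from compound 1 to compound 4 (0.05 log units; within the scatter). Compound 4 is therefore estimated at 20000 nM, between 8000 nM and 60000 nM.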

Compound 4, half-maximal inhibitory concentration: > 100000 nM
Compound 4: a limit, no number; the forecaster's own chance of this, stated with the estimate: 10%; at least 5.0-fold (0.69 log units) between middle value and limit.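

Exchanging fluoro for chloro, ortho to a large group, is not a neutral swap in this assay: this single change gives an at least 4.4-fold higher number from compound 1 to compound 4 (0.65 log units; beyond the scatter). The earlier compounds shown here compared only whole groups on the carbonyl carbon, whereas here one atom on the ring is enough to move the result beyond the scatter. The true size of the step stays unknown, since compound 4 sits at a limit of the assay and not at a number: the limit of > 100000 nM in this assay, at which 2 of the 4 values shown sit.

On these data alone, whether a methyl group, a methoxy group or an amine at this place would keep the value of compound 1 remains open. The compounds shown also cannot tell why fluoro and chloro part so clearly here.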